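Retinoid esters of phenolic acids: estimating a catechol analogue

This account rests on a few compounds, and the source may have more. Where it says the series, first, only, none or still open, it means among the compounds named here.

Measured compounds:
Compound 1, `CC(/C=C/C1=CCCCC1(C)C)=C\C=C\C(C)=C\COC(=O)c1cc(O)c(O)c(O)c1`: 27.5%
Compound 2, `COc1cc(O)c(C(=O)OC/C=C(C)/C=C/C=C(C)/C=C/C2=CCCCC2(C)C)c(O)c1`: 9.5%

In a functional assay on B16-F10 cells (Mus musculus) for inhibition, tested at 5 uM (a higher number here means more inhibition at the concentration tested (going by the name of the read-out), a lower number less inhibition), compound 1 gives 27.5%, while compound 2 gives 9.5%, the lower of the two numbers. For the measured compounds named here, the step of a number 18 percentage points lower from compound 1 to compound 2 (beyond the scatter) is the only measured step and it exchanges the aromatic ester group on the carbonyl carbon, the same place that changes now.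

Compound 3, `CC(/C=C/C1=CCCCC1(C)C)=C\C=C\C(C)=C\COC(=O)c1cccc(O)c1O`, is not yet measured. Its change from compound 2 is a group of 8 heavy atoms (6 carbon, 2 oxygen; one six-membered aromatic ring of carbon only) in place of a group of 10 heavy atoms (7 carbon, 3 oxygen; one six-membered aromatic ring of carbon only), on a carbonyl carbon

Going by the values given here, the one relevant step shows that altering the hydroxylated aromatic group on the carbonyl carbon shifts this assay by a modest amount beyond the scatter, and that compound 1, with three hydroxyls, sits above compound 2. Compound 3 carries two hydroxyls and no methoxy, so a move upward from compound 2 is expected, but of uncertain size given a single precedent. For compound 3 a value of 17% is estimated, within 2% to 35%, corresponding to an expected step of a number 7.5 percentage points higher from compound 2 to compound 3 (within the scatter).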

Compound 3, a percentage reported as inhibition, at one concentration (the size of the read-out at that concentration, not a potency): 18.6%
The estimate for compound 3 lay 1.6 percentage points below the measured number, within the range that was stated.
By their numbers in this assay, from the lowest: compounds 2, 3 and 1 (each within the scatter of the next, the first and the last beyond it).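

With 2,3-dihydroxyphenyl on the carbonyl carbon, this assay gives a number 9.1 percentage points higher from compound 2 to compound 3 (within the scatter) and a number 8.9 percentage points lower from compound 1 to compound 3 (within the scatter) for the two single exchanges at this place. Compound 3 therefore cannot be told apart from either compound 2 or compound 1, even though those two are separated by a number 18 percentage points lower from compound 1 to compound 2 (beyond the scatter) and the earlier pair alone had suggested a clear difference between aromatic groups. The group that leaves compound 2 and the group that enters compound 3 carry the same count of hydrogen-bond donors, and no information available here accounts for where compound 3 falls.

On these data alone, the three compounds change several ring substituents at once, so it remains open which single hydroxyl or methoxy group, if any, underlies the gap between compound 1 and compound 2. As far as these compounds go, it is also open whether an amine or a carboxylic acid on the aromatic ring would move this assay beyond the scatter, and how these readings at one concentration would translate into potency.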